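Compound 3 to compound 4: a larger aminocycloalkyl amide

The compounds below may be only part of what the source reports. "The series", "measured", "known", "first", "only" and "open" are said of these compounds alone.

Measured in a functional assay on NCI-H1975 cells (Homo sapiens) for antiproliferative activity (a lower number here means a stronger inhibitor, a higher number a weaker inhibitor), so far:
compound 1 `CC(=O)N1CCc2c(C)c3c(n2-c2ccc(C(N)=O)c(c2)N[C@@H](C)[C@H](C)C1)CC(C)(C)CC3=O` gives 15 nM
compound 2 `COCCC(=O)N1CCc2c(C)c3c(n2-c2ccc(C(N)=O)c(c2)N[C@@H](C)[C@H](C)C1)CC(C)(C)CC3=O` gives 31 nM
compound 3 `Cc1c2c(n3c1CCN(C(=O)C1(N)CC1)C[C@@H](C)[C@H](C)Nc1cc-3ccc1C(N)=O)CC(C)(C)CC2=O` gives 72 nM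

Compound 3 stands highest of the three, and its gaps to both others lie beyond the scatter. Compound 4 `Cc1c2c(n3c1CCN(C(=O)C1(N)CCCC1)C[C@@H](C)[C@H](C)Nc1cc-3ccc1C(N)=O)CC(C)(C)CC2=O` is still unmeasured and carries 1-aminocyclopentyl in place of 1-aminocyclopropyl on a carbonyl carbon. Three measured steps changed the group on that carbonyl carbon, and all were modest: a 2.1-fold higher number from compound 1 to compound 2 (0.32 log units; beyond the scatter) then a 4.8-fold higher number from compound 1 to compound 3 (0.68 log units; beyond the scatter) and finally a 2.3-fold higher number from compound 2 to compound 3 (0.37 log units; beyond the scatter) as the last of them. None of these exchanges 1-aminocyclopropyl for another ring of carbon only, so the data give no direct reading of this change. Their modest size argues against expecting a large step. In this assay the estimate is a 1.3-fold higher number from compound 3 to compound 4 (0.10 log units; within the scatter) and so no step beyond the scatter is expected. Compound 4 is expected at 90 nM (estimated range 35 nM to 230 nM).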

Compound 4, half-maximal inhibitory concentration: 26 nM
Estimate against measurement, compound 4: 3.5-fold (0.54 log units) above; measured number outside the range, below it.
By their numbers in this assay, from the lowest: compounds 1, 4 and 2 (each within the scatter of the next, the first and the last beyond it); then compound 3.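

Going from 1-aminocyclopropyl to 1-aminocyclopentyl on this carbonyl carbon gives a 2.8-fold lower number from compound 3 to compound 4 (0.44 log units; beyond the scatter) in this assay, so the weaker number of compound 3 does not extend to every 1-aminocycloalkyl amide and ring size matters here. Against the other acyl groups the scatter separates nothing: the data show a 1.2-fold lower number from compound 2 to compound 4 (0.08 log units; within the scatter) and a 1.7-fold higher number from compound 1 to compound 4 (0.24 log units; within the scatter), which places 1-aminocyclopentyl level with both 2-methoxyethyl and methyl, and leaves compound 3 as the only one of the three amino-free or amino-bearing comparisons beyond the scatter from compound 4. Nothing available accounts for this ring-size difference.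

Two ring sizes remain open: 1-aminocyclobutyl, which would fall between the two rings shown, and 1-aminocyclohexyl, which would extend the series upward. Also open, going by these compounds, is what the amine contributes, which plain cyclopentyl on the same carbonyl carbon would address.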